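The source may report more compounds than this note shows. Statements on the series, on what has been measured and on what is new or still open speak of the compounds shown alone.

In an ADME assay on cells (Splenocyte, Mus musculus, strain BALB/c) for cytotoxicity, read by CCK-8 assay, with a stated time of 48 h (a higher number here means that more compound is tolerated, a lower number that less compound is tolerated), compound 1 `COc1cc(-c2noc(-c3ccccc3)n2)cc(OC)c1OC` gives > 50000 nM, which is a limit of the assay rather than a number. Compound 2 `COc1cc(-c2noc(-c3ccc(N)cc3)n2)cc(OC)c1OC` gives > 50000 nM in this assay, again a limit and not a number. The step from compound 1 to compound 2 is accordingly a step that the two limits leave unreadable from compound 1 to compound 2. Compound 2 therefore stands at the limit of > 50000 nM in this assay, at which 2 of the 2 values shown sit, and nothing in the measured numbers separates it from compound 1. Compound 3 `COc1cc(-c2noc(-c3cccc(N)c3)n2)cc(OC)c1OC` differs from compound 2 only in where the amino group sits on the phenyl ring: 3-aminophenyl in place of 4-aminophenyl on an aromatic carbon. Among the measured compounds shown here, the single measured step bears on this change only in that its size could not be read. No step beyond the scatter is expected in a number no higher from compound 2 to compound 3 (the limit leaves the size open). Compound 3 is expected to reach the same limit in this assay. The estimate for compound 3 is 50000 nM, between 20000 nM and 100000 nM.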

Compound 3, half-maximal cytotoxic concentration: 8200 nM
Compound 3: the middle estimate sits 6.1-fold (0.79 log units) above what was measured, outside the stated range (below it).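

In this assay, moving the amino group gives the first readable difference in the series: the change to 3-aminophenyl from 4-aminophenyl is an at least 6.0-fold lower number from compound 2 to compound 3 (0.78 log units; beyond the scatter), so with the same atoms joined differently, the place of the amino group on the phenyl ring counts. Amino in place of hydrogen can now also be read at this place, as an at least 6.0-fold lower number from compound 1 to compound 3 (0.78 log units; beyond the scatter), whereas the same exchange giving the 4-aminophenyl of compound 2 left a step that cannot be read. Both steps give only a minimum size: the limit of > 50000 nM in this assay, at which 2 of the 3 values shown sit.

The compounds shown leave open whether the lower number belongs to the amino group itself or would also come with a hydroxyl, a methoxy or an acetamide at the same place on the phenyl ring. They also leave open how much larger the two steps really are.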